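Working notes: from isopropyl to pentyl on compound 3

The compounds below may be only part of what the source reports. "The series", "measured", "known", "first", "only" and "open" are said of these compounds alone.

Measured so far in a functional assay on MCF7 cells (Homo sapiens) for antiproliferative activity, with a stated time of 5 days (on this read-out lower numbers stand for stronger inhibition and higher numbers for weaker inhibition), for three compounds
- compound 1 `COc1ccc(-c2[nH]c3cc(F)ccc3c2C=O)cc1` gives 43 nM
- compound 2 `COc1ccc(-c2[nH]c3cc(Cl)ccc3c2C=O)cc1` gives 65 nM
- compound 3 `COc1ccc(-c2[nH]c3ccc(C(C)C)cc3c2C=O)cc1` gives 97 nM

Compound 3 at 97 nM lies within the scatter of compound 2 and beyond the scatter of compound 1 on the higher side. Compound 4 `CCCCCc1ccc2[nH]c(-c3ccc(OC)cc3)c(C=O)c2c1` has not yet been measured and differs from compound 3 by pentyl in place of isopropyl on an aromatic carbon with pentyl in place of isopropyl on an aromatic carbon. Within the data shown here, the only measured step in one place, a 1.5-fold higher number from compound 1 to compound 2 (0.18 log units; within the scatter) for chloro in place of fluoro on an aromatic carbon, stays within the scatter. Among the measured compounds shown here, it bears only loosely on this change, as no measured pair exchanges one alkyl chain for another. In this assay no step beyond the scatter is therefore expected, with a slight lean towards a higher number. The anchor is compound 3 at 97 nM and the range is kept wide. The estimated step is a 1.2-fold higher number from compound 3 to compound 4 (0.09 log units; within the scatter) on this thin evidence. For compound 4 the estimated value is 120 nM with an expected range from 40 nM to 350 nM pending measurement.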

Compound 4, half-maximal inhibitory concentration: 20 nM
For compound 4 the middle estimate is 6.0-fold (0.78 log units) above the measured one; measured number below the stated range.
By their numbers in this assay, from the lowest: compound 4; then compounds 1, 2 and 3 (each within the scatter of the next, the first and the last beyond it).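

In this assay the step of a 4.9-fold lower number from compound 3 to compound 4 (0.69 log units; beyond the scatter) is the first one-place change shown that lies beyond the scatter, and it arises with only the alkyl chain exchanged, pentyl in place of isopropyl on an aromatic carbon. The earlier step of a 1.5-fold higher number from compound 1 to compound 2 (0.18 log units; within the scatter) stays within the scatter, so this position is the first shown where the choice of group gives a clear difference in the number. No measured data are available to explain this difference.

As far as these compounds go, whether the lower number persists with a longer chain such as heptyl, or with a pentyl chain ending in an amine or a carboxylic acid, remains open. A single pair also cannot separate chain length from branching, and a straight propyl chain or a branched pentyl group would be needed to tell them apart.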